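This account rests on a few compounds, and the source may have more. Where it says the series, first, only, none or still open, it means among the compounds named here.

Compounds measured so far:
Compound 1, `CCn1ccc(N2C[C@H](CO)OC2=O)c1`, gives 3 nM in an assay for inhibition of Amine oxidase [flavin-containing] A (Bos taurus), read by fluorescence, with a stated time of 30 min; a higher number here means a weaker inhibitor, a lower number a stronger inhibitor.
Compound 2, `C=CCn1ccc(N2C[C@H](CO)OC2=O)c1`, gives 350 nM in this assay.

Compound 2 thus stands as the higher of the two numbers, the weaker inhibitor of the pair. Within the data shown here, the one measured step, a 120-fold higher number from compound 1 to compound 2 (2.07 log units; beyond the scatter), concerns a different part of the molecule. Compound 3, `C=CCn1ccc(N2C[C@H](CNC)OC2=O)c1`, differs from compound 2 by methylamino in place of hydroxy on a saturated chain carbon bound to a saturated ring carbon. Among the measured compounds shown here, no measured step covers a change of this kind, so the direction cannot be read from the data. The estimate for compound 3 in this assay is 1000 nM, between 150 nM and 7000 nM. That estimate means a step of a 2.9-fold higher number from compound 2 to compound 3 (0.46 log units; beyond the scatter), expected to be modest and uncertain.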

Compound 3, inhibition constant: 100 nM
Compound 3: middle estimate off by 10-fold (1.00 log units), on the high side, outside the stated range (below it).
By their numbers in this assay, from the lowest: compound 1; then compound 3; then compound 2.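

Methylamino in place of hydroxy on this saturated chain carbon, bound to a saturated ring carbon, gives a 3.5-fold lower number from compound 2 to compound 3 (0.54 log units; beyond the scatter) in this assay. This place on the molecule therefore also affects the number, and here the change makes compound 3 the stronger inhibitor, even though the counts of hydrogen-bond donors and acceptors stay the same. No available evidence explains this change. As far as these compounds go, a simple amine, dimethylamino or a longer chain at this place remains open, as does whether methylamino would give a similar step on compound 1.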